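A few compounds are considered here, and "the series" means these few. Any claim that something is new, unique, unknown or untested is made for them only; others in the source may bear on it.

Measured in a functional assay on MCF7 cells (Homo sapiens) for antiproliferative activity, read by CCK-8 assay, with a stated time of 48 h; on this read-out lower numbers stand for stronger inhibition and higher numbers for weaker inhibition:
- Compound 1 `O=C(/C=C/CNCCOc1ccc(Oc2c(-c3ccc(F)cc3)sc3cc(O)ccc23)cc1)N1CCCC1`: 7610 nM
- Compound 2 `C=C(C)C(=O)NCCOc1ccc(Oc2c(-c3ccc(F)cc3)sc3cc(O)ccc23)cc1`: > 25000 nM (a limit)
- Compound 3 `O=C(CCCNCCOc1ccc(Oc2c(-c3ccc(F)cc3)sc3cc(O)ccc23)cc1)N1CCC1`: > 25000 nM (a limit)

Compound 3 stands at > 25000 nM, which is a limit of the assay and not a number. This is the limit of > 25000 nM in this assay, at which 2 of the 3 values shown sit, so only compound 1 gives a measured number.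

Compound 4 `O=C(/C=C/CNCCOc1ccc(Oc2c(-c3ccc(F)cc3)sc3cc(O)ccc23)cc1)N1CCC1` has not yet been measured, and it departs from compound 3 in one place: 2-((azetidin-1-yl)carbonyl)ethenyl in place of 2-((azetidin-1-yl)carbonyl)ethyl on a saturated chain carbon bound to an amine nitrogen. The azetidine amide therefore stays, while the chain takes the ethenyl form found in compound 1.

The nearest evidence is an at least 3.2-fold higher number from compound 1 to compound 3 (0.51 log units; beyond the scatter). That step changes the pyrrolidine to the azetidine together with the ethenyl to the ethyl, and the data do not separate the two changes. A second step, an at least 3.2-fold higher number from compound 1 to compound 2 (0.51 log units; beyond the scatter), replaces the whole side chain and bears on the question only loosely. The step that the two limits leave unreadable from compound 2 to compound 3 adds nothing.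

Among the measured compounds shown here, compound 1, with 7610 nM, is the only measured compound bearing the ethenyl form, so a lower number is expected in this assay. The expected change is an at least 2.2-fold lower number from compound 3 to compound 4 (0.35 log units; beyond the scatter), of about the size seen in the nearest step. For compound 4 the estimated value is 11000 nM, with an expected range of 4500 nM to 25000 nM.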

Compound 4, half-maximal inhibitory concentration: 7340 nM
For compound 4 the middle estimate is 1.5-fold (0.18 log units) above the measured one; low and high end bracket the measured number.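

In this assay, among the compounds shown here, 2-((azetidin-1-yl)carbonyl)ethenyl in place of 2-((azetidin-1-yl)carbonyl)ethyl on a saturated chain carbon bound to an amine nitrogen gives an at least 3.4-fold lower number from compound 3 to compound 4 (0.53 log units; beyond the scatter) and so isolates the chain change with the azetidine amide held fixed, which the earlier compounds could not do. The ring change now stands apart as well: with the ethenyl form kept, azetidin-1-yl in place of pyrrolidin-1-yl on a carbonyl carbon gives a 1.0-fold lower number from compound 1 to compound 4 (0.02 log units; within the scatter) and leaves the two amides indistinguishable here. On an amine nitrogen, 3-((azetidin-1-yl)carbonyl)prop-2-en-1-yl in place of (1-methylethenyl)carbonyl gives an at least 3.4-fold lower number from compound 2 to compound 4 (0.53 log units; beyond the scatter), and this step and the chain step have only a minimum size because one end of each is a limit: the limit of > 25000 nM in this assay, at which 2 of the 4 values shown sit.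

The compounds shown leave open whether a piperidine amide or an open-chain dimethylamide on the same ethenyl chain would stay at this level, and whether a longer chain between the amine nitrogen and the amide would do so. They also leave open how a saturated chain carrying the pyrrolidine amide would read out.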